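Dropping a Methoxy Group: Expected Effect on Growth Inhibition

The source may hold more compounds than are shown below. What is called first, only, known or untested is meant among the compounds shown, and "the series" means these compounds.

Measured so far:
- compound 1, `N=C(N)c1ccc(-c2ccc(-c3cc(Cl)cc(Cl)c3)s2)s1`: 1960 nM
- compound 2, `COc1ccc(-c2ccc(-c3ccc(C(=N)N)o3)o2)cc1`: 2430 nM

Both compounds were tested in a functional assay on OVCAR-5 cells (Homo sapiens) for inhibition, read by sulforhodamine B assay, with a stated time of 48 h; a higher number here means a weaker inhibitor of growth, a lower number a stronger inhibitor of growth. Compound 2 gives 2430 nM, the highest of the two numbers shown. Its nearest neighbour is compound 1, which gives 1960 nM in this assay; the gap between the two lies within the usual scatter, so no order between them can be claimed.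

Compound 3, `N=C(N)c1ccc(-c2ccc(-c3ccccc3)o2)o1`, has not yet been measured. It differs from compound 2 in a single place: hydrogen in place of methoxy on an aromatic carbon. Going by the values given here, no step between two measured compounds isolates this particular change, so there is no direct reading of its size. Among the compounds with values here, the only guidance is that compound 1 and compound 2, which carry quite different groups on the outer ring, still sit close together in this assay.

The expected step is a 1.2-fold higher number from compound 2 to compound 3 (0.09 log units; within the scatter), most likely a small shift toward a slightly higher number, at the edge of the scatter rather than clearly beyond it. Compound 3 is therefore estimated at 3000 nM in this assay, with a range from 1200 nM to 8000 nM.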

Compound 3, concentration for 50% growth inhibition: 2700 nM
For compound 3 the middle estimate is 1.1-fold (0.05 log units) above the measured one; low and high end bracket the measured number.
By their numbers in this assay, from the lowest: compounds 1, 2 and 3 (each within the scatter of the next).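

Going by these compounds alone, this pair gives the first direct reading of this change: with hydrogen in place of methoxy on an aromatic carbon of the six-membered aromatic ring, para to a large group, the step is a 1.1-fold higher number from compound 2 to compound 3 (0.05 log units; within the scatter) in this assay on these cells. In this one pair, then, the position can lose the methoxy, with its carbon and its oxygen, and the loss cannot be told apart from the spread of repeated measurements, so the methoxy shows no measurable part in growth inhibition here. No separate measurement is available that would explain this result.

A single pair cannot show how other groups would read at this position: an amine, a carboxylic acid or a longer chain such as ethoxy could each stay within the scatter of hydrogen or move clearly beyond it. It also leaves open whether the same change would read the same way on a different core, such as the core of compound 1, since the result holds only for compound 2 and compound 3.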